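Three aryl ketones near the ceiling, and a thiophene successor

The source may hold more compounds than are shown below. What is called first, only, known or untested is meant among the compounds shown, and "the series" means these compounds.

Compound 1 `COc1cc(C(=O)C2Sc3nnc(-c4cc(OC)c(OC)c(OC)c4)n3NC2c2ccco2)cc(OC)c1OC` in a functional assay on MCF7 cells (Homo sapiens) for cytotoxicity, read by MTT assay, with a stated time of 48 h (on this read-out higher numbers stand for weaker inhibition and lower numbers for stronger inhibition), gives > 100000 nM, a limit of the assay.
Compound 2 `COc1cc(-c2nnc3n2NC(c2ccco2)C(C(=O)c2ccccc2F)S3)cc(OC)c1OC` in this assay gives 94800 nM.
Compound 3 `COc1cc(-c2nnc3n2NC(c2ccco2)C(C(=O)c2ccc(Br)cc2)S3)cc(OC)c1OC` in this assay gives > 100000 nM, a limit of the assay.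

Compound 3 thus stands only at a limit, sharing with compound 1 (the limit of > 100000 nM in this assay, at which 2 of the 3 values shown sit). The step of an at least 1.0-fold lower number from compound 1 to compound 2 (0.02 log units; that floor lies within the scatter) stays within the scatter, the step of an at least 1.0-fold higher number from compound 2 to compound 3 (0.02 log units; that floor lies within the scatter) likewise, and the step that the two limits leave unreadable from compound 1 to compound 3 cannot be read. Compound 4 `COc1cc(-c2nnc3n2NC(c2ccco2)C(C(=O)c2cccs2)S3)cc(OC)c1OC` differs from compound 3 by thiophen-2-yl in place of 4-bromophenyl on a carbonyl carbon. All three changes on the carbonyl carbon measured so far moved nothing beyond the scatter, so no step beyond the scatter is expected from compound 3 to compound 4, a number no higher from compound 3 to compound 4 (the limit leaves the size open). Compound 4 is therefore estimated at 100000 nM, between 50000 nM and 300000 nM, most likely reported again as a limit.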

Compound 4, half-maximal inhibitory concentration: > 100000 nM
Compound 4 gave a limit, no number; the forecaster's own chance of this, stated with the estimate: 70%; the middle value sits exactly at the limit.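

With thiophen-2-yl on the carbonyl carbon, a five-membered aromatic ring with a hetero atom joins the six-membered aryl rings at this position, and in this assay compound 4 still gives only a limit, > 100000 nM. The data show an at least 1.0-fold higher number from compound 2 to compound 4 (0.02 log units; that floor lies within the scatter), while the remaining new steps cannot be read. The ceiling now holds most of the set: the limit of > 100000 nM in this assay, at which 3 of the 4 values shown sit.

From the compounds shown here alone, whether an amine or a carboxylic acid in place of the ring on the carbonyl carbon would give a value clear of this limit stays open. Any difference among the compounds at the limit also stays open.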